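The compounds below may be only part of what the source reports. "The series", "measured", "known", "first", "only" and "open" are said of these compounds alone.

Measured compounds:
- compound 1, `COc1cc(C2=NN(C(C)=O)C(c3cccc(F)c3)O2)cc(OC)c1OC`: 14.7%
- compound 2, `COc1cc(C(=O)N/N=C/c2ccccc2C(F)(F)F)cc(OC)c1OC`: 22.1%

Both were tested in a functional assay on BGC-823 cells (Homo sapiens) for antiproliferative activity, read by MTT assay, tested at 1 uM; on this read-out higher numbers stand for a stronger effect at the one concentration tested and lower numbers for a weaker effect. In this assay compound 1 gives 14.7%, and compound 2 gives 22.1%; the two numbers lie within the usual scatter of each other, so neither can be called the stronger. Compound 2 is built on a different, open-chain core, so it offers no single-point comparison to compound 1.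

Compound 3, `COc1cc(C2=NN(C(C)=O)C(c3ccccc3C(F)(F)F)O2)cc(OC)c1OC`, keeps the core of compound 1 and changes one group: 2-(trifluoromethyl)phenyl in place of 3-fluorophenyl on a saturated ring carbon. For the measured compounds named here, no measured pair shows what such a change does on this core. The step of a number 3.3 percentage points higher from compound 1 to compound 3 (within the scatter) is therefore expected to be small, with no clear direction beyond the scatter. For compound 3 the estimated read-out in this assay is 18%, within a range from 5% to 35%.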

Compound 3, a percentage reported as inhibition, at one concentration (the size of the read-out at that concentration, not a potency): 31.8%
Beside the measured number, compound 3's estimate is 13.8 percentage points below it, within the range that was stated.
By their numbers in this assay, from the lowest: compounds 1, 2 and 3 (each within the scatter of the next, the first and the last beyond it).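

In this assay, the swap to 2-(trifluoromethyl)phenyl from 3-fluorophenyl on the saturated ring carbon gives a number 17.1 percentage points higher from compound 1 to compound 3 (beyond the scatter). This shows that, on the core of compound 1, the read-out responds modestly to the group at this position. The swap alters both the substituent and its place on the phenyl ring, so this one step cannot separate the two, and no supporting measurement explains the rise.

The compounds shown leave open how a plain phenyl ring, or a phenyl ring carrying an amine or a carboxylic acid, would behave at this position. They also leave open whether the step would hold at other concentrations, since each number here comes from a single concentration and is not a potency.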